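The source may report more compounds than this note shows. Statements on the series, on what has been measured and on what is new or still open speak of the compounds shown alone.

Compound 1, `CCNCC(=O)Nc1cc(OC)ccc1C(=O)c1ccc(OC)c2c1OC(C)(C)C=C2`, gives 1980 nM in a functional assay on A2780 cells (Homo sapiens) for antiproliferative activity, read by MTT assay, with a stated time of 48 h; a lower number here means a stronger inhibitor, a higher number a weaker inhibitor.
Compound 2, `COc1ccc(C(=O)c2ccc(OC)c3c2OC(C)(C)C=C3)c(NC(=O)CN(C)C)c1`, gives 790 nM in this assay.
Compound 3, `C=C(c1ccc(OC)cc1NC(=O)CNCC)c1ccc(OC)c2c1C=CC(C)(C)O2`, gives 2010 nM in this assay.

Compound 4, `C=C(c1ccc(OC)cc1NC(=O)CN(C)C)c1ccc(OC)c2c1C=CC(C)(C)O2`, has not yet been measured in this assay. It is reached from compound 3 by one change, (dimethylamino in place of ethylamino on a saturated chain carbon bound to a carbonyl carbon). The same change, (dimethylamino in place of ethylamino on a saturated chain carbon bound to a carbonyl carbon), joins compound 1 to compound 2, where it gave a 2.5-fold lower number from compound 1 to compound 2 (0.40 log units; beyond the scatter). The place of the change is described in the same words for both pairs, so the change counts as the same one and not merely as one of the same kind. Compound 1 and compound 3 share the remainder of their structures in the sense that their cores differ, but how the two cores differ is not broken down here. Their values in this assay lie within the scatter of each other, so nothing can be said about which is the stronger of the two.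

With one measured example of the change, the expectation for compound 4 rests on that single step. Compound 4 is expected to show a 2.4-fold lower number from compound 3 to compound 4 (0.37 log units; beyond the scatter) in this assay because compound 1 gave a 2.5-fold lower number from compound 1 to compound 2 (0.40 log units; beyond the scatter) when the same change was made. Within the data shown here, compound 4 is therefore estimated at about 850 nM in this assay, with a likely range from 400 nM to 1800 nM, the width of the range reflecting that only one prior instance of the change supports it.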

Compound 4, half-maximal inhibitory concentration: 670 nM
Compound 4: the middle estimate sits 1.3-fold (0.10 log units) above what was measured; measured number inside the range.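

In this assay, putting dimethylamino in place of ethylamino on the saturated chain carbon bound to a carbonyl carbon gave a 3.0-fold lower number from compound 3 to compound 4 (0.48 log units; beyond the scatter), so the lower number seen on the core of compound 1 also appeared on the core of compound 3. Set side by side, the two steps cannot be told apart, and on these two cores the change carried over with much the same size: the same change on two cores in this assay, a 2.5-fold lower number (0.40 log units; beyond the scatter) from compound 1 to compound 2 and a 3.0-fold lower number (0.48 log units; beyond the scatter) from compound 3 to compound 4, 1.2-fold (0.08 log units) apart, within the scatter of two such steps. Among these compounds, this is only two pairs, however, so it sets no rule for other cores, and although dimethylamino has no hydrogen-bond donor where ethylamino has one, the pairs do not show whether that difference is what matters, or why the number falls at all.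

The compounds shown leave open how other amines on the same chain carbon would compare on either core, such as methylamino, diethylamino, or a ring amine like pyrrolidine or morpholine. They also leave open whether dimethylamino would give a similar step on a longer chain, or on a core other than these two.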